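From a Phenoxy Tail to Imidazolyl: Expected Paw Edema Inhibition

The compounds below may be only part of what the source reports. "The series", "measured", "known", "first", "only" and "open" are said of these compounds alone.

Compound 1 `Cc1ccc(-c2cc(C(=O)Oc3ccc(C(C)(C)C)cc3)n(Cc3ccccc3)n2)cc1` gives 50% in a functional assay on the whole organism (strain Swiss albino) for inhibition, with Mus musculus as the target, read by paw edema, with stated times of 30 min and 270 min, at a dose of 100 mg/kg by the subcutaneous route; a higher number here means more inhibition at the dose given (going by the name of the read-out), a lower number less inhibition.
Compound 2 `Cc1ccc(-c2cc(C(=O)Oc3ccc(C(C)C)cc3)n(Cc3ccccc3)n2)cc1` gives 29% in this assay.
Compound 3 `Cc1ccc(-c2cc(C(=O)Oc3ccc(Oc4ccc(C(F)(F)F)cc4)cc3)n(Cc3ccccc3)n2)cc1` gives 22.2% in this assay.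

Compound 3 stands lowest of the three numbers. Its closest neighbour is compound 2, since the step is a number 6.8 percentage points lower from compound 2 to compound 3 (within the scatter), so the two cannot be told apart. The gap to compound 1 is real: the step is a number 27.8 percentage points lower from compound 1 to compound 3 (beyond the scatter). The other measured step, a number 21 percentage points lower from compound 1 to compound 2 (beyond the scatter), concerns only the size of the alkyl group and does not involve compound 3.

Compound 4 `Cc1ccc(-c2cc(C(=O)Oc3ccc(-n4ccnc4)cc3)n(Cc3ccccc3)n2)cc1` has not yet been measured. It differs from compound 3 in one place: 1H-imidazol-1-yl in place of 4-(trifluoromethyl)phenoxy on an aromatic carbon. Both measured steps that bear on this position, a number 27.8 percentage points lower from compound 1 to compound 3 (beyond the scatter) and a number 6.8 percentage points lower from compound 2 to compound 3 (within the scatter), describe the arrival of the 4-(trifluoromethyl)phenoxy group in place of a small alkyl, one a modest drop and one within the scatter. For the measured compounds named here, no measured compound carries an imidazolyl group, so there is no direct guide to its effect. With the group that leaves having cost at most a modest amount, a small recovery is plausible but not assured; the step for compound 4 is expected to be a number 5.8 percentage points higher from compound 3 to compound 4 (within the scatter), within the scatter. Compound 4 is therefore estimated at 28%, with a range from 10% to 48%.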

Compound 4, a percentage reported as inhibition, in the whole organism at one dose (the size of the read-out at that dose, not a potency): 19.2%
The estimate for compound 4 lay 8.8 percentage points above the measured number; low and high end bracket the measured number.
By their numbers in this assay, from the lowest: compounds 4, 3 and 2 (each within the scatter of the next); then compound 1.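

Replacing 4-(trifluoromethyl)phenoxy, with 11 heavy atoms and a six-membered ring of carbon only, by 1H-imidazol-1-yl, with 5 heavy atoms and a five-membered ring holding 2 hetero atoms, gives a number 3 percentage points lower from compound 3 to compound 4 (within the scatter) in this assay, so these two quite different groups on this aromatic carbon cannot be told apart in this read-out. The isopropyl group cannot be told apart from 1H-imidazol-1-yl either, with a number 9.8 percentage points lower from compound 2 to compound 4 (within the scatter), while the tert-butyl group stands clear, with a number 30.8 percentage points lower from compound 1 to compound 4 (beyond the scatter), making compound 1 the only one of the four separated from all the others. No measured property of these groups is available to account for this picture.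

The compounds shown leave open whether the higher number of compound 1 belongs to tert-butyl itself or would also come with another bulky hydrocarbon group such as cyclohexyl. They also leave open where a plain hydrogen, an amine or a carboxylic acid on this aromatic carbon would fall, whether with compound 1 or with the other three.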